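From an Ethyl to a Chloro Group on a Shared Core

The source may report more compounds than this note shows. Statements on the series, on what has been measured and on what is new or still open speak of the compounds shown alone.

Within the data shown here, compound 2 `CCc1ccc(S(=O)(=O)Nc2ccc(-c3nc4ccccc4o3)cc2)cc1` is one of three compounds measured in an assay on cells for inhibition of HSP60/HSP10 (Homo sapiens), with a stated time of 60 min; on this read-out higher numbers stand for weaker inhibition and lower numbers for stronger inhibition. In this assay compound 2 reaches only a limit, > 100000 nM. Compound 1 `O=S(=O)(Nc1ccc2oc(-c3ccccc3)nc2c1)c1ccccc1O` gives 85000 nM in this assay. Compound 3 `O=S(=O)(Nc1ccc2oc(-c3ccccc3)nc2c1)c1ccccc1F` gives only a limit, > 100000 nM. Among the measured compounds shown here, the single measured step, an at least 1.1-fold higher number from compound 1 to compound 3 (0.07 log units; that floor lies within the scatter), is fluoro in place of hydroxy on an aromatic carbon, and its size is bounded by the limit of > 100000 nM in this assay, at which 2 of the 3 values shown sit. Compound 4 `O=S(=O)(Nc1ccc(-c2nc3ccccc3o2)cc1)c1ccc(Cl)cc1` differs from compound 2 by chloro in place of ethyl on an aromatic carbon. For the measured compounds named here, no measured step touches this change, and compound 2 already sits at the limit. Compound 4 is therefore expected to move no further than the scatter, a number no higher from compound 2 to compound 4 (the limit leaves the size open). The estimate for compound 4 is 100000 nM, ranging from 40000 nM to 300000 nM.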

Compound 4, half-maximal inhibitory concentration: 61000 nM
Compound 4: the middle estimate sits 1.6-fold (0.21 log units) above what was measured; the measured number falls inside the stated range.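

On the aromatic carbon para to a large group, 4-chlorophenyl in place of 4-ethylphenyl gives this core a measured number rather than a limit: in this assay compound 4 gives 61000 nM. The change reads an at least 1.6-fold lower number from compound 2 to compound 4 (0.21 log units; that floor lies within the scatter), so only a floor is known, and a real gain in strength is not shown. The true size of the step stays bounded: the limit of > 100000 nM in this assay, at which 2 of the 4 values shown sit.

On these data alone, whether an amine, a carboxylic acid or a longer chain at this place would move the number beyond the scatter remains open.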